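Methoxy for chloro in compound 4: expected cytotoxicity

This account rests on a few compounds, and the source may have more. Where it says the series, first, only, none or still open, it means among the compounds named here.

Measured so far in a functional assay on HeLa cells (Homo sapiens) for cytotoxicity, read by MTT assay, with a stated time of 72 h; a lower number here means a stronger inhibitor, a higher number a weaker inhibitor:
- Compound 1 `CCOc1ccc(COc2c(OC)cc(/C=C/C(=O)OCC(=O)Nc3ccccc3)cc2OC)cc1` gives > 200000 nM in this assay; this is a limit of the assay, not a number.
- Compound 2 `COCOc1cc(/C=C/C(=O)OCC(=O)Nc2ccc(Cl)cc2)ccc1OCc1ccccc1` gives > 200000 nM in this assay; again a limit.
- Compound 3 `O=C(COC(=O)/C=C/c1ccc(O)c(O)c1)NN1CCOCC1` gives > 200000 nM in this assay; again a limit.

Compound 2 therefore stands at the limit of this assay; the other two values shown are limits as well, and there is nothing in the numbers to set one compound apart from another. Among the measured compounds shown here, the only evidence across the set is the limit of > 200000 nM in this assay, at which 3 of the 3 values shown sit. For the measured compounds named here, no pair of measured compounds differs in a single place, so no measured step gives the size of any structural change in this assay.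

Compound 4 `COCOc1cc(/C=C/C(=O)OCC(=O)Nc2ccc(OC)cc2)ccc1OCc1ccccc1` differs from compound 2 in one place: methoxy in place of chloro on an aromatic carbon. With every measured value sitting at the limit, the expectation for the step from compound 2 to compound 4 in this assay is no change beyond the usual scatter, in either direction, which is what the estimate a step that the limit leaves unreadable from compound 2 to compound 4 expresses. Compound 4 is accordingly expected to give about 300000 nM in this assay, with a range from 100000 nM to 1000000 nM, and most likely to return only a limit again.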

Compound 4, half-maximal inhibitory concentration: 155000 nM
For compound 4 the middle estimate is 1.9-fold (0.29 log units) above the measured one, and the stated range covers the measured number.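

Going from 4-chlorophenyl to 4-methoxyphenyl yields the first value in the set that is a number and not a limit: in this assay compound 4 gives 155000 nM, which makes this position on the ring the first place in the series where a reading can be taken at all. The change of chloro to methoxy reads as an at least 1.2-fold lower number from compound 2 to compound 4 (0.11 log units; that floor lies within the scatter), and that is only a floor, so the data do not establish a shift beyond the scatter. The true size of the step remains unknown because compound 2 returns only a limit: the limit of > 200000 nM in this assay, at which 3 of the 4 values shown sit.

As far as these compounds go, whether an amine, a carboxylic acid or a longer chain such as butoxy in place of the methoxy of compound 4 would give a clearly lower number in this assay remains open, as does whether any group at this position can move the series far from the top of the measurable range. Also open, from the compounds shown here alone, is whether 4-methoxyphenyl would give a number on the core of compound 1, which differs from compound 4 in more than one place.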